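A few compounds are considered here, and "the series" means these few. Any claim that something is new, unique, unknown or untested is made for them only; others in the source may bear on it.

Measured so far in an in vitro ADME assay on microsomes from liver (Macaca mulatta) for metabolic stability, tested at 5 uM; a higher number here means that the compound lasts longer, a lower number that the compound disappears faster:
compound 1 `CC(C)(C)Cc1nn(CCC2CC2)c(=O)c(C2=NS(=O)(=O)c3cc(NS(C)(=O)=O)ccc3N2)c1O`: > 1 h
compound 2 `CC(C)(C)CCn1nc(CC(C)(C)C)c(O)c(C2=NS(=O)(=O)c3cc(NS(C)(=O)=O)ccc3N2)c1=O`: 0.117 h

For the measured compounds named here, compound 2 holds the only number in this assay. For compound 1 the value is a limit of the assay (the limit of > 1 h in this assay, at which 1 of the 2 values shown sits). Going by the values given here, the single measured step, an at least 8.5-fold lower number from compound 1 to compound 2 (0.93 log units; beyond the scatter), concerns the chain group and not the aromatic carbon.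

Compound 3 `CC(C)=Cc1nn(CCC(C)(C)C)c(=O)c(C2=NS(=O)(=O)c3cc(NS(C)(=O)=O)ccc3N2)c1O` differs from compound 2 by 2-methylprop-1-en-1-yl in place of neopentyl on an aromatic carbon. Among the compounds with values here, no measured step touches this position, so the change is taken as neutral, with a step of a 1.2-fold lower number from compound 2 to compound 3 (0.07 log units; within the scatter) expected. Compound 3 is estimated at 0.1 h, between 0.04 h and 0.3 h.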

Compound 3, half-life: 0.283 h
Estimate against measurement, compound 3: 2.8-fold (0.45 log units) below; the measured number falls inside the stated range.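

Swapping neopentyl for 2-methylprop-1-en-1-yl on the aromatic carbon gives a 2.4-fold higher number from compound 2 to compound 3 (0.38 log units; beyond the scatter) in this assay, so this position is not neutral in this assay. The earlier step concerned only the chain on the aromatic nitrogen, and this one shows that the group on the aromatic carbon also moves the half-life. Nothing measured here accounts for the step.

Still open, on these data alone, is how an amine or a carboxylic acid on this aromatic carbon would behave. Also open, as far as these compounds go, is whether the same swap gives a similar step when cyclopropyl replaces tert-butyl on the chain.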